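This account rests on a few compounds, and the source may have more. Where it says the series, first, only, none or still open, it means among the compounds named here.

Working notes on the series. Compound 1 `CC1=CC[C@@H]([C@@](C)(O)CCCC(C)(C)NC(=S)NN)CC1` gives only a limit in a functional assay on OVCAR-3 cells (Homo sapiens) for cytotoxicity, read by sulforhodamine B assay (on this read-out lower numbers stand for higher toxicity in this test and higher numbers for lower toxicity in this test), namely > 100000 nM (the limit of > 100000 nM in this assay, at which 1 of the 3 values shown sits). Compound 2 `COc1ccc(/C=N\NC(=S)NC(C)(C)CCC[C@](C)(O)[C@@H]2CC=C(C)CC2)cc1` gives 46200 nM in this assay, and compound 3 `CC1=CC[C@@H]([C@@](C)(O)CCCC(C)(C)NC(=S)N/N=C\c2ccc(O)cc2)CC1` gives 54400 nM. Compound 3 and compound 2 sit within the scatter of each other, a 1.2-fold higher number from compound 2 to compound 3 (0.07 log units; within the scatter), so neither stands apart. Compound 4 `CC1=CC[C@@H]([C@@](C)(O)CCCC(C)(C)NC(=S)N/N=C\c2cccc([N+](=O)[O-])c2)CC1` differs from compound 3 by 3-nitrophenyl in place of 4-hydroxyphenyl on a carbon with a double bond to nitrogen. Within the data shown here, no measured step involves a nitro group on the aromatic ring; the one step that alters that ring, a 1.2-fold higher number from compound 2 to compound 3 (0.07 log units; within the scatter), was within the scatter, while an at least 2.1-fold lower number from compound 1 to compound 2 (0.33 log units; beyond the scatter) and an at least 1.8-fold lower number from compound 1 to compound 3 (0.26 log units; that floor lies within the scatter) show only that either aromatic group lowers the number from the limit. The expected step is therefore a 1.2-fold lower number from compound 3 to compound 4 (0.08 log units; within the scatter), within the scatter. Compound 4 is estimated at 45000 nM, with a range of 20000 nM to 100000 nM.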

Compound 4, concentration lethal to 50% of the cells: > 100000 nM
Compound 4: a limit, no number; the forecaster's own chance of this, stated with the estimate: 20%; middle value at least 2.2-fold (0.34 log units) from the limit.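

Among the aromatic groups on the carbon with a double bond to nitrogen, the choice now matters in this assay: 3-nitrophenyl in place of 4-methoxyphenyl gives an at least 2.1-fold higher number from compound 2 to compound 4 (0.33 log units; beyond the scatter), while 3-nitrophenyl in place of 4-hydroxyphenyl gives an at least 1.8-fold higher number from compound 3 to compound 4 (0.26 log units; that floor lies within the scatter). An aromatic ring at this carbon therefore does not by itself lower the number, as compounds 2 and 3 alone had suggested, and compound 4 goes against that pattern. The reading for compound 4 is a limit, not a number, as is that for compound 1: the limit of > 100000 nM in this assay, at which 2 of the 4 values shown sit. From the compounds shown here alone, whether the nitro group itself or its place on the ring decides the outcome stays open. A 4-nitrophenyl group or an amine on the ring would help to separate the two.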